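The compounds below may be only part of what the source reports. "The series", "measured", "known", "first", "only" and "open" are said of these compounds alone.

Compound 1 `COc1ccc(Nc2nc(SCc3cn(Cc4ccccc4Cl)nn3)nc(-c3ccccc3)c2C#N)cc1` gives 8050 nM in a functional assay on MCF7 cells (Homo sapiens) for inhibition, read by MTT assay, with a stated time of 72 h; a higher number here means a weaker inhibitor, a lower number a stronger inhibitor.
Compound 2 `Cc1cccc(Nc2nc(SCc3cn(Cc4ccccc4Cl)nn3)nc(-c3ccccc3)c2C#N)c1` gives 19600 nM in this assay.

Among the compounds with values here, compound 1 has the lowest number of the two; the one step measured, a 2.4-fold higher number from compound 1 to compound 2 (0.39 log units; beyond the scatter), concerns the group on the nitrogen and is of modest size. Compound 3 `COc1ccc(Nc2nc(SCc3cn(Cc4ccccc4Cl)nn3)nc(-c3ccc(C(C)C)cc3)c2C#N)cc1` differs from compound 1 in another place: isopropyl in place of hydrogen on an aromatic carbon. Within the data shown here, no measured step touches that phenyl ring, so the measured pair offers no guide for this change; the only information is that a modest alteration elsewhere moved the number by a modest amount. In this assay compound 3 is therefore expected to land near compound 1, with the direction undecided and a step, if any, of the modest kind seen so far. The expected step is a 1.2-fold lower number from compound 1 to compound 3 (0.09 log units; within the scatter). For compound 3 the estimate is 6500 nM, within 1600 nM to 26000 nM.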

Compound 3, half-maximal inhibitory concentration: 10300 nM
Estimate against measurement, compound 3: 1.6-fold (0.20 log units) below; measured number inside the range.
By their numbers in this assay, from the lowest: compounds 1, 3 and 2 (each within the scatter of the next, the first and the last beyond it).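

In this assay, placing isopropyl on an aromatic carbon, para to a large group, gives a 1.3-fold higher number from compound 1 to compound 3 (0.11 log units; within the scatter) and so leaves compound 3 indistinguishable from compound 1. Within the data shown here, this is the first reading at this position, and it shows that the change from phenyl to 4-isopropylphenyl, which adds 3 carbon atoms and no ring, does not produce a step beyond the scatter. No supporting measurement accounts for this result.

Going by these compounds, one substituent cannot show how far this tolerance extends, so it remains open whether an amine, a carboxylic acid or a longer chain in the same place would also stay within the scatter of compound 1. On these data alone, it is also open whether isopropyl would give a similar step alongside the 3-methylphenyl group of compound 2.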